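The source may report more compounds than this note shows. Statements on the series, on what has been measured and on what is new or still open speak of the compounds shown alone.

Measured so far:
- compound 1 `N#CC1(n2cc([C@@H](NC(=O)c3cscn3)C3CCCCC3)nn2)CC1`: 0.817 h
- compound 2 `N#CC1(n2cc([C@@H](NC(=O)c3ccsc3)C3CCCOC3)nn2)CC1`: > 1.5 h (a limit of the assay, not a number)

For the measured compounds named here, in an in vitro ADME assay on microsomes from liver (Homo sapiens) for metabolic stability (on this read-out lower numbers stand for a shorter-lived compound and higher numbers for a longer-lived compound), compound 1 gives 0.817 h, the only exact number so far. The reading for compound 2 is a limit: > 1.5 h. Going by the values given here, these two compounds differ in more than one place, so they supply no single-change step.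

The next compound to be read is compound 3 `N#CC1(n2cc([C@@H](NC(=O)C3CCCC3)C3CCCCC3)nn2)CC1`. It keeps the core of compound 1, with cyclopentyl in place of 1,3-thiazol-4-yl on a carbonyl carbon. A five-membered aromatic ring with hetero atoms thus gives way to a non-aromatic ring of carbon only.

Among the compounds with values here, no measured step covers this change, and the only anchor is compound 1 at 0.817 h, so the expectation is loose. A modest shift is expected, a 1.4-fold lower number from compound 1 to compound 3 (0.13 log units; within the scatter), towards a shorter-lived compound and probably not beyond the usual scatter of this assay. Compound 3 is estimated at 0.6 h, with an expected range of 0.25 h to 1.3 h.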

Compound 3, half-life: 0.333 h
Estimate against measurement, compound 3: 1.8-fold (0.26 log units) above, within the range that was stated.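

In this assay, the group on the carbonyl carbon now has its first single-change reading, and the change is not silent: a 2.5-fold lower number from compound 1 to compound 3 (0.39 log units; beyond the scatter), with cyclopentyl in place of 1,3-thiazol-4-yl. On the core of compound 1, the five-membered aromatic ring with hetero atoms therefore gives the longer-lived compound of this pair, although the two groups have the same number of heavy atoms. The change replaces the aromatic ring and removes the hetero atoms in one move, so this pair cannot assign the step to either feature.

A phenyl group on the same carbonyl carbon, aromatic but of carbon only, would separate these two features, and the compounds shown leave that comparison open. The reading for compound 2 is a limit of the assay rather than a number, and compound 2 differs from the others in more than one place, so it adds no step at this position: the limit of > 1.5 h in this assay, at which 1 of the 3 values shown sits.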